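The source may hold more compounds than are shown below. What is called first, only, known or untested is meant among the compounds shown, and "the series" means these compounds.

Measured so far:
- compound 1 `COc1cc(C#N)cc(-c2c(C)nn(-c3nc(-c4ccc(Cl)c(Cl)c4)c(SC(C)C)s3)c2C(=O)O)c1` — 5200 nM
- compound 2 `Cc1c(-c2cc(Cl)cc(Cl)c2)c(C(=O)O)nn1-c1nc(-c2ccc3nccn3c2)c(SC(C)C)s1` — "not active" (no number reported)
- compound 3 `Cc1nn(-c2nc(-c3ccc(Cl)c(Cl)c3)c(SC(C)C)s2)c(C(=O)O)c1-c1cc(C(F)(F)F)cc(C(F)(F)F)c1` — 1800 nM

Three members of the series have been tested in a functional assay on BJAB cells (Homo sapiens) for antiproliferative activity, with a stated time of 4 days; on this read-out higher numbers stand for an effect only at larger amounts of compound and lower numbers for an effect already at smaller amounts. Compound 1 gives 5200 nM, the highest of the two numbers reported. The nearest entry is compound 3, which gives 1800 nM in this assay, a lower number that lies beyond the scatter of the method. Among the compounds with values here, compound 2 is reported in this assay as "not active" (no number reported), with no number attached, and differs from compound 1 in more than one place, so it offers no step of its own. Within the data shown here, no pair of measured compounds differs in a single place; every comparison here rests on more than one change at once.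

Compound 4 `Cc1cccc(-c2c(C)nn(-c3nc(-c4ccc(Cl)c(Cl)c4)c(SC(C)C)s3)c2C(=O)O)c1` is the next candidate. It differs from compound 1 in one place: 3-methylphenyl in place of 3-cyano-5-methoxyphenyl on an aromatic carbon

Among the measured compounds shown here, nothing among the measured compounds isolates this kind of change on the shared core of compound 1. For the measured compounds named here, the only guidance is that compound 1 sits at the weak end of the reported numbers and compound 3 shows that another aryl group at this place can give a lower number. A step of modest size is expected for compound 4, from compound 1 toward a somewhat lower number, but one that could as well fall within the scatter; the expectation is written as a 1.3-fold lower number from compound 1 to compound 4 (0.11 log units; within the scatter). For compound 4 in this assay the estimate is 4000 nM, with a range from 1300 nM to 12000 nM.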

Compound 4, half-maximal effective concentration: 17000 nM
Beside the measured number, compound 4's estimate is 4.3-fold (0.63 log units) below it; measured number above the stated range.
By their numbers in this assay, from the lowest: compound 3; then compound 1; then compound 4.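

In this assay, within the data shown here, this is the first step on the shared core that changes one place only, on the aromatic carbon of the five-membered ring with 2 nitrogen: 3-methylphenyl in place of 3-cyano-5-methoxyphenyl gives a 3.3-fold higher number from compound 1 to compound 4 (0.51 log units; beyond the scatter), a step beyond the scatter. The aryl group at this carbon therefore matters to the read-out, and losing the nitrile and the methoxy while gaining a methyl moves the number upward, a direction now read from a single pair and not from compounds that differ in several places. No measurement bearing on why the number shifts is available for this pair.

Going by these compounds, whether the step belongs to the nitrile, to the methoxy or to the methyl remains open: 3-cyanophenyl and 3-methoxyphenyl would separate these contributions on the core of compound 1. Also open, on these data alone, is how an aminomethyl group or a longer alkyl chain on this aryl ring would read out in this assay, and whether the direction of this step would hold on a core carrying a different group in place of the 3,4-dichlorophenyl.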